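Aryl replacement at the amide of compound 2

This account rests on a few compounds, and the source may have more. Where it says the series, first, only, none or still open, it means among the compounds named here.

Going by the values given here, compound 2 `Cc1cccc(C(=O)Nc2c(C(O)(C(F)(F)F)C(F)(F)F)ccc3ccccc23)c1` gives the lowest of the two numbers so far in an assay on LtK cells with ATP-sensitive inward rectifier potassium channel 11 (Homo sapiens) as the target (on this read-out higher numbers stand for an effect only at larger amounts of compound and lower numbers for an effect already at smaller amounts), at 23 nM; compound 1 `O=C(Nc1c(C(O)(C(F)(F)F)C(F)(F)F)ccc2ccccc12)C1CC1` gives 751 nM. Among the compounds with values here, the only measured step, a 33-fold lower number from compound 1 to compound 2 (1.51 log units; beyond the scatter), concerns the group on the carbonyl carbon. Compound 3 `O=C(Nc1c(C(O)(C(F)(F)F)C(F)(F)F)ccc2ccccc12)c1ccc(OC(F)(F)F)cc1` carries 4-(trifluoromethoxy)phenyl in place of 3-methylphenyl on a carbonyl carbon. Within the data shown here, no measured step compares two aryl groups on the carbonyl carbon, so the size of this aryl-to-aryl change cannot be read from the data. Since an aryl group remains, a modest step is expected, a 1.7-fold higher number from compound 2 to compound 3 (0.24 log units; within the scatter). For compound 3 in this assay the estimate is 40 nM, ranging from 12 nM to 130 nM.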

Compound 3, half-maximal effective concentration: > 10000 nM
Compound 3: a limit, no number (the forecaster's own chance of this, stated with the estimate: 2%); at least 250-fold (2.39 log units) between middle value and limit.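

An aryl group on the carbonyl carbon does not by itself give a low number: in this assay compound 3 reaches only a limit, > 10000 nM, and not a number. Exchanging 3-methylphenyl for 4-(trifluoromethoxy)phenyl gives an at least 430-fold higher number from compound 2 to compound 3 (2.63 log units; beyond the scatter), so the gain seen with 3-methylphenyl does not carry over to every aryl group. This aryl group also falls behind cyclopropyl, with an at least 13-fold higher number from compound 1 to compound 3 (1.12 log units; beyond the scatter).

Going by these compounds, whether the loss follows the trifluoromethoxy group or its place on the ring remains open. A 4-methylphenyl group and a 3-(trifluoromethoxy)phenyl group on the same carbonyl carbon would separate the two.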